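Swapping an ethylphenyl amide for a pyridyl amide

The source may hold more compounds than are shown below. What is called first, only, known or untested is meant among the compounds shown, and "the series" means these compounds.

Compound 3 `CCc1cccc(NC(=O)CN2CCN(c3ccc(Cl)cn3)CC2)c1` has so far given no number at all in an assay on cells for agonist activity at D(4) dopamine receptor (Homo sapiens), read by luminescence and beta-arrestin recruitment, with a stated time of 90 min; a higher number here means a larger maximal response, a lower number a smaller maximal response: for compound 3 the result is recorded as "not active" (no number reported). The closely related compound 2 `Cc1cccc(NC(=O)CN2CCN(c3ccc(Cl)cn3)CC2)c1` fared the same, with "not active" (no number reported) in this assay. Within the data shown here, the only measured analogue with a number is compound 1 `O=C(CN1CCN(c2ccccn2)CC1)Nc1cccnc1`, which in this assay gives 19%. Compound 4 `O=C(CN1CCN(c2ccc(Cl)cn2)CC1)Nc1cccnc1` is the next case, with a change computed as pyridin-3-yl in place of 3-ethylphenyl on an amide-type nitrogen. Among the measured compounds shown here, since compound 3 has no number, no size of step can be set out; the expectation is a small maximal response of the kind compound 1 shows with 19%. Compound 4 is expected to reach 15%, within 0% to 35%.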

Compound 4, largest response reached (Emax), in percent of the reference or control that the assay uses: "not active" (no number reported)
The entry for compound 4 holds no number, and the estimate cannot be compared.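

In this assay compound 3 and compound 4 are both recorded as not active, so no step can be read between them, and no measurement on hand offers an explanation. From the compounds shown here alone, whether 3-ethylphenyl or pyridin-3-yl gives the larger maximal response stays open.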